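A few compounds are considered here, and "the series" means these few. Any claim that something is new, unique, unknown or untested is made for them only; others in the source may bear on it.

Measured so far:
compound 1 `c1ccc(-c2cn3ccnc3c(-c3ccc4ncn(C5CCCCC5)c4c3)n2)cc1` — 23.8% in a functional assay on Hs-578T cells (Homo sapiens) for inhibition, read by sulforhodamine B assay, with a stated time of 48 h, tested at 10 uM; on this read-out lower numbers stand for less inhibition and higher numbers for more inhibition at the one concentration tested (going by the name of the read-out)
compound 2 `c1ccc2c(-c3cn4ccnc4c(-c4ccc5ncn(C6CCCCC6)c5c4)n3)cccc2c1` — 3.62% in this assay

Going by the values given here, compound 2 holds the lower of the two numbers; the only measured step, a number 20.2 percentage points lower from compound 1 to compound 2 (beyond the scatter), separates it from compound 1, the nearest and only neighbour.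

Compound 3 `Brc1ccc(-c2cn3ccnc3c(-c3ccc4ncn(C5CCCCC5)c4c3)n2)cc1` is not yet measured. It differs from compound 2 by 4-bromophenyl in place of naphthalen-1-yl on an aromatic carbon. Among the compounds with values here, the one step that bears on this change is a number 20.2 percentage points lower from compound 1 to compound 2 (beyond the scatter): replacing phenyl by naphthalen-1-yl lowered inhibition by a modest amount beyond the scatter. Compound 3 moves back to a single six-membered ring of carbon only, now carrying bromine. Within the data shown here, no measured pair shows what the bromine adds, so the expectation rests on reversing the measured step only. A rise of about a number 16.4 percentage points higher from compound 2 to compound 3 (beyond the scatter) is therefore expected for compound 3, landing near the level of compound 1. The estimate for compound 3 is 20%, with a range of 4% to 38%.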

Compound 3, a percentage reported as inhibition, at one concentration (the size of the read-out at that concentration, not a potency): 24.5%
Compound 3: middle estimate off by 4.5 percentage points, on the low side; the range from low to high includes it.
By their numbers in this assay, from the lowest: compound 2; then compounds 1 and 3 (each within the scatter of the next).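

In this assay, 4-bromophenyl in place of naphthalen-1-yl gives a number 20.9 percentage points higher from compound 2 to compound 3 (beyond the scatter) and so separates compound 3 from compound 2 at this aromatic carbon, a second single-ring comparison beside the step from phenyl. Bromo in place of hydrogen gives a number 0.7 percentage points higher from compound 1 to compound 3 (within the scatter) and therefore shows no readable effect of the bromine here, leaving compound 2 with naphthalen-1-yl apart from the two compounds with one six-membered aromatic ring of carbon only. No measurement is available that accounts for either step.

As far as these compounds go, whether an amine, a carboxylic acid or a methoxy group on the phenyl ring would also stay level with compound 1 remains open. Also open, from the compounds shown here alone, is whether naphthalen-2-yl would match compound 2 or the single-ring compounds.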